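Dihydrofuran carboxamide series: amide to acid at compound 1

A few compounds are considered here, and "the series" means these few. Any claim that something is new, unique, unknown or untested is made for them only; others in the source may bear on it.

Measured so far:
- compound 1, `C=CC1=C(C(=O)NCCC)C(c2ccc(Cl)c(Cl)c2)OC1`: 31300 nM
- compound 2, `C=CC1=C(C(=O)NCc2ccc(C)cc2)C(c2ccc(OC)cc2)OC1`: 43100 nM

Two compounds of the shared core have been run in a functional assay on QGY7701 cells (Homo sapiens) for cytotoxicity, read by MTT assay, with a stated time of 24 h; a lower number here means a stronger inhibitor, a higher number a weaker inhibitor. Compound 1 gives 31300 nM and compound 2 gives 43100 nM; compound 1 shows the lower of the two numbers, but the gap to compound 2 lies within the scatter, so the two stand level as far as the data go. Both are weak in this assay. Within the data shown here, compound 2 differs from compound 1 in more than one place, so no single step between measured compounds can be read off, and nothing is yet known about what the amide substituent contributes.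

The next compound, compound 3, `C=CC1=C(C(=O)O)C(c2ccc(Cl)c(Cl)c2)OC1`, differs from compound 1 in one place: hydroxy in place of propylamino on a carbonyl carbon. Among the measured compounds shown here, no step of this kind has been measured, so any expectation rests only on the weak number of compound 1 itself. A modest movement toward a weaker inhibitor, or none beyond the scatter, is expected, with the step from a 1.6-fold higher number from compound 1 to compound 3 (0.20 log units; within the scatter) as the working guess. Compound 3 is accordingly estimated at 50000 nM, in the range 15000 nM to 160000 nM.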

Compound 3, half-maximal inhibitory concentration: > 100000 nM
Compound 3: a limit, no number; the forecaster's own chance of this, stated with the estimate: 25%; middle value at least 2.0-fold (0.30 log units) from the limit.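

Hydroxy in place of propylamino on a carbonyl carbon is the first single-place change that can be read in the series, and it gives an at least 3.1-fold higher number from compound 1 to compound 3 (0.50 log units; beyond the scatter). In this assay compound 3 gives > 100000 nM, which is a limit of the assay and not a number. This place is therefore not indifferent to substitution, since the carboxy compound loses the measurable value that the propylcarbamoyl compound retains, and the true size of the step remains unread, since the reading stops at a limit: the limit of > 100000 nM in this assay, at which 1 of the 3 values shown sits.

Going by these compounds, what remains open is whether the loss belongs to the carboxylic acid itself or simply to the removal of the propyl chain, a question that a primary amide, a methyl ester or a longer chain on the same carbonyl carbon would help to separate. With a single step at this place and the core of compound 1 otherwise unchanged, the data also do not say how a cyclic amine in the amide, such as morpholine, would compare with propylamino, or whether any amide substituent can move the series away from its weak numbers.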